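Phenyl for Methyl on a Shared Indazole Amine Core

This account rests on a few compounds, and the source may have more. Where it says the series, first, only, none or still open, it means among the compounds named here.

Measured so far:
Compound 1 `ONc1ccc(CNc2cc(Br)cc3[nH]ncc23)cc1`: 6%
Compound 2 `CC(C)Nc1cc(Br)cc2[nH]ncc12`: "not active" (no number reported)

In an assay for inhibition of Tryptophan 2,3-dioxygenase (Homo sapiens), with a stated time of 1 h, tested at 10 uM (on this read-out higher numbers stand for more inhibition at the one concentration tested (going by the name of the read-out) and lower numbers for less inhibition), compound 1 gives 6%. In this assay compound 2 gives "not active" (no number reported), so no single number fixes where compound 2 stands; it is reported as not active there. Compound 3 `CC(Nc1cc(Br)cc2[nH]ncc12)c1ccccc1` differs from compound 2 by phenyl in place of methyl on a saturated chain carbon bound to a nitrogen on an aromatic ring and a saturated chain carbon. For the measured compounds named here, no measured step covers this change, so any shift in this assay is expected to be small, in either direction, and possibly not beyond the scatter. Compound 3 is expected to give about 10%, with a range from 0% to 30%.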

Compound 3, a percentage reported as inhibition, at one concentration (the size of the read-out at that concentration, not a potency): "not active" (no number reported)
Compound 3 has no reported number here; there is nothing to compare the estimate with.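

Compound 2 and compound 3 both lack a reported number, so no step can be read between them. The compounds shown leave open whether phenyl in place of methyl changes inhibition at all. No supporting measurement bears on this result.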